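From Acetyl to Propylcarbonyl: Compound 2 to Compound 3

The source may hold more compounds than are shown below. What is called first, only, known or untested is meant among the compounds shown, and "the series" means these compounds.

Compound 1 `COc1ccc(N)c(C2=NN(C(C)=O)C(C)(C)S2)c1`: 77.1%
Compound 2 `CC(=O)N1N=C(c2cc(Cl)ccc2N)SC1(C)C`: 72.8%

In an assay on isolated protein for inhibition of Nitric oxide synthase, inducible (Homo sapiens), read by scintillation counting, with a stated time of 30 min, tested at 50 uM (on this read-out higher numbers stand for more inhibition at the one concentration tested (going by the name of the read-out) and lower numbers for less inhibition), compound 1 gives 77.1% and compound 2 gives 72.8%. Within the data shown here, compound 2 has the lower of the two numbers, but the only step recorded, a number 4.3 percentage points lower from compound 1 to compound 2 (within the scatter), lies within the scatter. Compound 3 `CCCC(=O)N1N=C(c2cc(Cl)ccc2N)SC1(C)C` differs from compound 2 by ethyl in place of hydrogen on a saturated chain carbon bound to a carbonyl carbon. Among the measured compounds shown here, the one measured step concerns an aromatic substituent and does not bear on this change, so in this assay no step beyond the scatter is expected, an estimated change of a number 2.8 percentage points lower from compound 2 to compound 3 (within the scatter). Compound 3 is therefore estimated at 70%, with a range from 50% to 88%.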

Compound 3, a percentage reported as inhibition, at one concentration (the size of the read-out at that concentration, not a potency): 66.2%
Estimate against measurement, compound 3: 3.8 percentage points above, and the stated range covers the measured number.
By their numbers in this assay, from the lowest: compounds 3, 2 and 1 (each within the scatter of the next, the first and the last beyond it).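

In this assay, among these compounds, the change from acetyl to propylcarbonyl gives a number 6.6 percentage points lower from compound 2 to compound 3 (within the scatter) and so provides the first reading at this place, on a saturated chain carbon bound to a carbonyl carbon. Here, ethyl in place of hydrogen produces no step beyond the scatter. No available evidence bears on this result.

Going by these compounds, whether a longer chain or an amine at this place would give a step beyond the scatter remains open. So does whether ethyl in place of hydrogen would read the same with methoxy in place of chloro on the aromatic carbon.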